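Replacing cyclohexyl with 3,5-dimethylbenzyl: notes on compound 4

A few compounds are considered here, and "the series" means these few. Any claim that something is new, unique, unknown or untested is made for them only; others in the source may bear on it.

Values in a functional assay on A2780 cells (Homo sapiens) for cytotoxicity, read by MTT assay, with a stated time of 72 h (on this read-out lower numbers stand for stronger inhibition and higher numbers for weaker inhibition), as measured so far
- compound 1 `Cc1cc(C)cc(C(=O)N(CCCCCC(=O)Nc2ccccc2N)CC(=O)NC2CCCCC2)c1` at 42000 nM
- compound 2 `Nc1ccccc1NC(=O)CCCCCN(CC(=O)NC1CCCCC1)C(=O)c1cccc2ccccc12` at 18100 nM
- compound 3 `Nc1ccccc1NC(=O)CCCCCN(CC(=O)NC1CCCCC1)C(=O)c1ccccc1` at 181000 nM

Compound 1 stands in the middle of the three numbers, with compound 2 lower and compound 3 higher. Compound 4 `Cc1cc(C)cc(CNC(=O)CN(CCCCCC(=O)Nc2ccccc2N)C(=O)c2cc(C)cc(C)c2)c1` keeps the 3,5-dimethylphenyl on the carbonyl carbon and differs elsewhere: 3,5-dimethylbenzyl in place of cyclohexyl on an amide-type nitrogen and so 3,5-dimethylbenzyl sits in place of cyclohexyl on an amide-type nitrogen.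

Among the measured compounds shown here, no measured step covers this place. The three steps available all lie on the carbonyl carbon: a 2.3-fold lower number from compound 1 to compound 2 (0.37 log units; beyond the scatter) and a 4.3-fold higher number from compound 1 to compound 3 (0.63 log units; beyond the scatter) and also a 10-fold higher number from compound 2 to compound 3 (1.00 log units; beyond the scatter) in this series. They show that this assay can move with the aromatic group at that other place, and compound 3, the phenyl member, has the highest number. On that indirect evidence a modest step to a lower number is expected, though the direction remains uncertain. The expected step is a 2.3-fold lower number from compound 1 to compound 4 (0.37 log units; beyond the scatter) on this estimate. For compound 4 the estimated value is 18000 nM within an expected range of 5000 nM to 60000 nM in this series.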

Compound 4, half-maximal inhibitory concentration: 5100 nM
Estimate against measurement, compound 4: 3.5-fold (0.55 log units) above; the range from low to high includes it.
By their numbers in this assay, from the lowest: compound 4; then compound 2; then compound 1; then compound 3.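

In this assay, the amide-type nitrogen, which carries cyclohexyl throughout compound 1, compound 2 and compound 3, now also proves to be a place that moves the read-out: 3,5-dimethylbenzyl in place of cyclohexyl gives an 8.2-fold lower number from compound 1 to compound 4 (0.92 log units; beyond the scatter). The entering group brings an aromatic ring where the leaving group has a non-aromatic one, and 9 heavy atoms against 6, and this single pair cannot separate ring type from size. Nothing available explains the step.

Open, from the compounds shown here alone, is whether the two methyl groups matter, a question for an unsubstituted benzyl or a phenethyl group on this nitrogen. Also open, going by these compounds, is whether the lower number carries over when 3,5-dimethylbenzyl is paired with the naphthalen-1-yl of compound 2 or the phenyl of compound 3.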